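The source may hold more compounds than are shown below. What is called first, only, known or untested is meant among the compounds shown, and "the series" means these compounds.

Within the data shown here, compound 2 `CC(C)COC(=O)Nc1ccc([Se]C#N)cc1` gives 8100 nM in a functional assay on HT-29 cells (Homo sapiens) for cytotoxicity, read by MTT assay, with a stated time of 72 h (on this read-out higher numbers stand for weaker inhibition of growth and lower numbers for stronger inhibition of growth), the lower of the two numbers so far; compound 1 `CCCOC(=O)Nc1ccc([Se]C#N)cc1` gives 28400 nM. Among the measured compounds shown here, the one measured step, a 3.5-fold lower number from compound 1 to compound 2 (0.54 log units; beyond the scatter), came from adding a methyl branch to the chain. Compound 3 `C=CCOC(=O)Nc1ccc([Se]C#N)cc1` differs from compound 2 by vinyl in place of isopropyl on a saturated chain carbon bound to an oxygen next to a carbonyl group, so the branch is removed and the chain is shortened to the allyl of three carbons. For the measured compounds named here, only the step from compound 1 to compound 2 bears on this; the expectation is a modest rise, a 2.5-fold higher number from compound 2 to compound 3 (0.39 log units; beyond the scatter), back toward compound 1. Compound 3 is expected at 20000 nM, within 6000 nM to 60000 nM.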

Compound 3, concentration for 50% growth inhibition: 24500 nM
Beside the measured number, compound 3's estimate is 1.2-fold (0.09 log units) below it; the measured number falls inside the stated range.
By their numbers in this assay, from the lowest: compound 2; then compounds 3 and 1 (each within the scatter of the next).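

Going from isobutyl to allyl removes what the methyl branch gained (in this assay, a 3.0-fold higher number from compound 2 to compound 3 (0.48 log units; beyond the scatter)), so the branched compound 2 stands apart from both unbranched chains. Vinyl in place of ethyl makes no readable difference (a 1.2-fold lower number from compound 1 to compound 3 (0.06 log units; within the scatter)), so at this place the double bond does not match the effect of the branch. No measured evidence accounts for either step.

Open, going by these compounds, is how a longer branched chain or a benzyl group in place of isobutyl would read, and whether the branch itself or the larger chain sets compound 2 apart.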